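This account rests on a few compounds, and the source may have more. Where it says the series, first, only, none or still open, it means among the compounds named here.

The three measured compounds share one core, shown for compound 1 as `CCCCCN1C(=O)C/C(=C\c2cccc(C(=O)Nc3cccc(F)c3)c2)C1=O`, for compound 2 as `COc1ccc(NC(=O)c2cccc(/C=C3\CC(=O)N(c4ccc(C)cc4)C3=O)c2)cc1` and for compound 3 as `COc1ccc(NC(=O)c2cccc(/C=C3\CC(=O)N(c4ccccc4)C3=O)c2)c(C)c1`. All three were tested in an ADME assay on SW480 cells (Homo sapiens) for cytotoxicity, read by MTT assay, with a stated time of 72 h; a lower number here means a stronger inhibitor, a higher number a weaker inhibitor. Compound 1 returns only a limit of this assay, > 100000 nM. Compound 2 gives a number, 93000 nM. Compound 3 again returns only a limit, > 100000 nM, so for compound 3 no number is known. Two of the three values shown therefore sit at the limit of > 100000 nM in this assay, at which 2 of the 3 values shown sit, and the one number shown, for compound 2, is not far from it. Among the compounds with values here, none of the measured compounds differs from another in a single place, so no measured step is available as a guide.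

Compound 4, `Cc1ccc(NC(=O)c2cccc(/C=C3\CC(=O)N(c4ccccc4)C3=O)c2)cc1`, has not yet been tested in this assay. It differs from compound 3 in one place: 4-methylphenyl in place of 4-methoxy-2-methylphenyl on an amide-type nitrogen. With compound 3 at a limit and every value shown weak in this assay, the change is expected to give no step beyond the scatter, the expected step being a number no higher from compound 3 to compound 4 (the limit leaves the size open). Compound 4 is thus estimated at about 100000 nM, within a range from 40000 nM to 250000 nM, and is likely to come back as a limit once more.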

Compound 4, half-maximal inhibitory concentration: > 100000 nM
Compound 4 was reported as a limit; the forecaster's own chance of this, stated with the estimate: 65%; the middle value sits exactly at the limit.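

Compound 3 and compound 4 both return only limits in this assay, so no step can be read between them, and the change from 4-methoxy-2-methylphenyl to 4-methylphenyl has no readable size. The compounds shown leave open whether any change to the shared core would give a clearly stronger inhibitor in this assay, with most values held at one point: the limit of > 100000 nM in this assay, at which 3 of the 4 values shown sit.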